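From 4-methylphenyl to 4-fluorophenyl on a shared core

The source may hold more compounds than are shown below. What is called first, only, known or untested is meant among the compounds shown, and "the series" means these compounds.

In a functional assay on MCF7 cells (Homo sapiens) for antiproliferative activity, read by MTT assay, with a stated time of 72 h (a higher number here means a weaker inhibitor, a lower number a stronger inhibitor), compound 1 (`COc1ncc(-c2ccc3c(c2)N(c2ccc(C)cc2)C(=O)CO3)cc1NS(=O)(=O)c1ccc(F)cc1`) gives 15400 nM and compound 2 (`COc1ccc(N2C(=O)COc3ccc(-c4ccc(O)cc4)cc32)cc1`) gives 17300 nM on a related structure. These two numbers lie within the scatter of each other, so compound 1 stands level with compound 2 and neither can be ranked ahead. Within the data shown here, both sit in the same high range, and nothing measured so far shows how a single change moves the read-out.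

Compound 3 (`COc1ncc(-c2ccc3c(c2)N(c2ccc(F)cc2)C(=O)CO3)cc1NS(=O)(=O)c1ccc(F)cc1`) keeps the core of compound 1 and differs in one place: fluoro in place of methyl on an aromatic carbon with fluoro in place of methyl on an aromatic carbon, para to a large group. Among the measured compounds shown here, no measured pair here tests this change, or any other single change. For the measured compounds named here, the expectation therefore rests on compound 1 at 15400 nM as the only close neighbour, and no shift beyond the scatter is expected in this assay for this swap. The estimated step, a 1.1-fold lower number from compound 1 to compound 3 (0.04 log units; within the scatter), is small and has no firm direction. Compound 3 is expected at about 14000 nM (estimated range 6000 nM to 30000 nM).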

Compound 3, half-maximal inhibitory concentration: > 40000 nM
Compound 3: a limit, no number; the forecaster's own chance of this, stated with the estimate: 10%; middle value at least 2.8-fold (0.45 log units) from the limit.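

Among these compounds, the change from 4-methylphenyl to 4-fluorophenyl on the shared core is the first single change that can be read in this assay, and it gives an at least 2.5-fold higher number from compound 1 to compound 3 (0.41 log units; beyond the scatter). This shows that the position on an aromatic carbon, para to a large group, is not indifferent to what sits there: with fluoro in place of methyl, the inhibitor is weaker by more than the scatter, which compound 1 and compound 2, differing in more than one place, could not show. For compound 3 the read-out is a limit and not a number, so the step gives only a lower bound on the size of the change: the limit of > 40000 nM in this assay, at which 1 of the 3 values shown sits.

With a single pair at this position, the compounds shown leave open whether a chloro group, an ethyl group or an amine in the same place would keep the number near that of compound 1 or push it to the limit seen for compound 3. They also leave open whether the swap from methyl to fluoro would move the number in the same direction on a different core.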